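The compounds below may be only part of what the source reports. "The series", "measured", "known", "first", "only" and "open" are said of these compounds alone.

Working notes on the series. Compound 1 `CCN(CC)C(=S)SCC(O)Cn1c([N+](=O)[O-])cnc1C` gives 2460000 nM in a toxicity assay on HeLa cells (Homo sapiens) for cytotoxicity, read by MTT assay, with a stated time of 24 h; on this read-out higher numbers stand for weaker inhibition and lower numbers for stronger inhibition; compound 2 `CCCCN1CCN(C(=S)SCC(O)Cn2c([N+](=O)[O-])cnc2C)CC1` gives 1910000 nM in this assay; compound 3 `COc1ccccc1N1CCN(CC(O)Cn2c([N+](=O)[O-])cnc2C)CC1` gives 4390000 nM in this assay. Compound 3 thus holds the highest of the three numbers: its number and that of compound 1 lie within the scatter of each other, whereas its number stands beyond the scatter above that of compound 2. Compound 4 `Cc1ncc([N+](=O)[O-])n1CC(O)CN1CCN(c2ccco2)CC1` differs from compound 3 in one place: furan-2-yl in place of 2-methoxyphenyl on an amine nitrogen in a ring. Among the measured compounds shown here, no measured pair shows this change, so its effect in this assay is unknown. For compound 4 the expected step in this assay from compound 3 is a 1.3-fold lower number from compound 3 to compound 4 (0.10 log units; within the scatter), amounting to no change beyond the scatter. Compound 4 is therefore estimated at 3500000 nM in this assay, within 1500000 nM to 8000000 nM.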

Compound 4, half-maximal inhibitory concentration: 3520000 nM
Compound 4: the middle estimate sits 1.0-fold (0.00 log units) below what was measured; the measured number falls inside the stated range.
By their numbers in this assay, from the lowest: compounds 2, 1, 4 and 3 (each within the scatter of the next, the first and the last beyond it).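

Furan-2-yl in place of 2-methoxyphenyl on an amine nitrogen in a ring gives the first readable step at this position, a 1.2-fold lower number from compound 3 to compound 4 (0.10 log units; within the scatter) in this assay. Going from 8 heavy atoms to 5, and from a six-membered aromatic ring of carbon only to a five-membered aromatic ring with 1 hetero atom, thus leaves the number within the scatter. No measurement on hand accounts for this outcome. Still open, going by these compounds, is whether a non-aromatic group at this place, such as a carboxylic acid or a primary amine, would move the number beyond the scatter.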